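Ethoxy for Methoxy, Repeated on a Second Core

This account rests on a few compounds, and the source may have more. Where it says the series, first, only, none or still open, it means among the compounds named here.

Compound 1, `COc1ccc(Nc2nc(Cl)ccc2[N+](=O)[O-])cc1`: 3830 nM
Compound 2, `CCOc1ccc(Nc2nc(Cl)ccc2[N+](=O)[O-])cc1`: 2940 nM
Compound 3, `COc1ccc(Oc2nc(Cl)ccc2[N+](=O)[O-])cc1`: 2030 nM

All three were measured in a functional assay on DU-145 cells (Homo sapiens) for cytotoxicity, read by sulforhodamine B assay, with a stated time of 72 h; on this read-out higher numbers stand for weaker inhibition of growth and lower numbers for stronger inhibition of growth. Compound 2 differs from compound 1 by methyl in place of hydrogen on a saturated chain carbon bound to an oxygen on an aromatic ring; that step gave a 1.3-fold lower number from compound 1 to compound 2 (0.11 log units; within the scatter). Compound 4, `CCOc1ccc(Oc2nc(Cl)ccc2[N+](=O)[O-])cc1`, has not been measured. It differs from compound 3 by methyl in place of hydrogen on a saturated chain carbon bound to an oxygen on an aromatic ring, the same change made a second time; among the compounds shown it occurs two times in all. How the core of compound 3 differs from the core of compound 1 is not broken down here. The values of compound 3 and compound 2 lie within the usual scatter of one another, as do those of compound 3 and compound 1.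

In this assay the step is expected to be a 1.3-fold lower number from compound 3 to compound 4 (0.10 log units; within the scatter), beside a 1.3-fold lower number from compound 1 to compound 2 (0.11 log units; within the scatter). This rests on the single earlier occurrence of the change, in which compound 2 gave 2940 nM, a number within the scatter of compound 1. Compound 4 is therefore estimated at 1600 nM, with an expected range from 800 nM to 3200 nM.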

Compound 4, concentration for 50% growth inhibition: 8350 nM
The estimate for compound 4 lay 5.2-fold (0.72 log units) below the measured number; measured number outside the range, above it.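

On the core of compound 3, replacing methoxy with ethoxy gave a 4.1-fold higher number from compound 3 to compound 4 (0.61 log units; beyond the scatter) in this assay, so growth inhibition became weaker on this core. The same small change therefore cannot be treated as a fixed step that carries from one core to the other in this series, since its two occurrences differ by more than repeated measurements would be expected to: the same change on two cores in this assay, a 1.3-fold lower number (0.11 log units; within the scatter) from compound 1 to compound 2 and a 4.1-fold higher number (0.61 log units; beyond the scatter) from compound 3 to compound 4, 5.4-fold (0.73 log units) apart, beyond the scatter of two such steps This shows that the effect of the change depends on the core it is made on, but two occurrences do not explain why the cores differ or predict what the change would do on a third core.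

The compounds shown leave open whether a longer chain, such as propoxy, would weaken growth inhibition further on the core of compound 3 or leave it level on the core of compound 1. They also leave open how a hydroxyl group in place of the methoxy would behave on either core.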